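Swapping ethoxycarbonyl for cyano on a shared core

A few compounds are considered here, and "the series" means these few. Any claim that something is new, unique, unknown or untested is made for them only; others in the source may bear on it.

Compound 1 `CCOC(=O)c1sc(N2CCCC2)nc1Cl` gives 79000 nM
Compound 2 `O=C(c1ccccc1)c1sc(N2CCCC2)nc1Cl` gives 63000 nM

Both numbers come from a functional assay on MCF7 cells (Homo sapiens) for cytotoxicity, read by MTT assay, with a stated time of 72 h; a lower number here means a stronger inhibitor, a higher number a weaker inhibitor. Compound 1 has only compound 2 to stand against, and the two cannot be ranked, since the gap between them lies within the scatter.

Compound 3 `N#Cc1sc(N2CCCC2)nc1Cl` keeps the core of compound 1 and changes one group, (cyano in place of ethoxycarbonyl on an aromatic carbon). In words, this is cyano in place of ethoxycarbonyl on an aromatic carbon, next to the ring sulfur.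

Within the data shown here, no measured step shows this exact swap. The closest evidence is the replacement of ethoxy by phenyl on a carbonyl carbon, which gave a 1.3-fold lower number from compound 1 to compound 2 (0.10 log units; within the scatter) as its result. That step kept the carbonyl, whereas cyano removes it, so it is only indirect support. No step beyond the scatter is therefore expected in this assay, although such thin evidence calls for a wide range. This estimate gives a 1.1-fold lower number from compound 1 to compound 3 (0.05 log units; within the scatter) as the expected step. Compound 3 is estimated at 70000 nM, with an expected range from 25000 nM to 150000 nM.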

Compound 3, half-maximal inhibitory concentration: 99000 nM
Compound 3: the middle estimate sits 1.4-fold (0.15 log units) below what was measured; the range from low to high includes it.
By their numbers in this assay, from the lowest: compounds 2, 1 and 3 (each within the scatter of the next).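

In this assay, putting cyano in place of ethoxycarbonyl on the aromatic carbon next to the ring sulfur gives a 1.3-fold higher number from compound 1 to compound 3 (0.10 log units; within the scatter), a step that cannot be told apart from the ordinary spread of repeated measurements. The earlier step changed only what was attached to the carbonyl, whereas here the carbonyl itself is gone and a group of 5 heavy atoms gives way to one of 2, yet this assay still shows no clear change at this position. No measurement at hand offers an explanation for this result.

The compounds shown leave open whether any group at this position can move the number beyond the scatter, for example a carboxylic acid, a primary amide or an aminomethyl group. From the compounds shown here alone, the pyrrolidin-1-yl and chloro groups are the same in all three compounds, so it also remains open what would follow from putting a diethylamino group in place of pyrrolidin-1-yl, or a bromine atom in place of chloro.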